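The source may hold more compounds than are shown below. What is called first, only, known or untested is meant among the compounds shown, and "the series" means these compounds.

Measured compounds:
- compound 1, `CNc1nccc(N2CC[C@H](NC(=O)Nc3ccc(Cl)c(C(F)(F)F)c3)C2)n1` — in an assay on a protein complex for displacement of a labelled ligand from CDK8/Cyclin C (Homo sapiens), read by TR-FRET, with a stated time of 1 h (on this read-out higher numbers stand for weaker inhibition and lower numbers for stronger inhibition), compound 1 gives 10.1 nM
- compound 2, `CNc1nccc(N2CC[C@H](NC(=O)Nc3ccc(CN4CCC4)c(C(F)(F)F)c3)C2)n1` — in this assay compound 2 gives 99.9 nM

Compound 1 stands at the lowest of the two numbers; its nearest neighbour is compound 2, and the step of a 9.9-fold higher number from compound 1 to compound 2 (1.00 log units; beyond the scatter) sets them apart with (azetidin-1-yl)methyl in place of chloro on an aromatic carbon.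

Compound 3, `CCNc1nccc(N2CC[C@H](NC(=O)Nc3ccc(Cl)c(C(F)(F)F)c3)C2)n1`, has not been measured. It differs from compound 1 by methyl in place of hydrogen on a saturated chain carbon bound to a nitrogen on an aromatic ring — that is, methylamino becomes ethylamino on the shared core. For the measured compounds named here, no measured step touches this part of the molecule: the only step in hand, from compound 1 to compound 2, alters the aryl substituent on the urea, not the amine on the core, so it gives no direct guide. With nothing to show that this small extension matters, the expectation for compound 3 is a number close to that of compound 1, a step of a 1.2-fold higher number from compound 1 to compound 3 (0.07 log units; within the scatter) that may well fall within the scatter. The estimate for compound 3 in this assay is 12 nM, with a range from 5 nM to 30 nM.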

Compound 3, half-maximal inhibitory concentration: 8.9 nM
Compound 3: the middle estimate sits 1.3-fold (0.13 log units) above what was measured; measured number inside the range.
By their numbers in this assay, from the lowest: compounds 3 and 1 (each within the scatter of the next); then compound 2.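

In this assay, for the compounds shown here, the step of a 1.1-fold lower number from compound 1 to compound 3 (0.05 log units; within the scatter) is the first reading at the amine on the shared core, where methylamino becomes ethylamino, and it shows that adding a methyl on this saturated chain carbon leaves the number within the scatter. Going by these compounds alone, the only earlier step, a 9.9-fold higher number from compound 1 to compound 2 (1.00 log units; beyond the scatter), lies beyond the scatter but changes the aryl substituent on the urea, so the two compounds now show a change at each of these two places on compound 1, and only the one at the aryl substituent moves the number beyond the scatter. The data offer no evidence on why the ethylamino group leaves the number within the scatter.

The compounds shown leave open how far this position can be extended, since ethyl is the largest group seen there, and whether a longer chain such as propyl, a branched group such as isopropyl, a ring such as cyclopropyl or a chain ending in a hydroxyl group would also stay within the scatter of compound 1. They also leave open whether ethylamino would give the same small step on a core carrying (azetidin-1-yl)methyl in place of chloro.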